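Replacing isopropyl with bromo in a urea series

The source may report more compounds than this note shows. Statements on the series, on what has been measured and on what is new or still open speak of the compounds shown alone.

Measured compounds in this assay:
compound 1, `CC(C)c1ccccc1NC(=O)N[C@H](C)c1ccccc1`: 101%
compound 2, `CC(C)c1ccccc1NC(=O)N[C@@H](C)c1ccccc1`: 96%
compound 3, `CCCCCCc1ccc(NC(=O)N[C@@H](C)c2ccccc2)cc1`: 100%

Three ureas have been measured in an ADME assay on the whole organism with Oryza sativa as the target, tested at 1 uM; a higher number here means a weaker effect of the compound at the concentration tested, a lower number a stronger effect. Compound 1 gives 101%, compound 2 gives 96%, and compound 3 gives 100%. Compound 2 is set apart from neither of the other two: the gaps to compound 1 and to compound 3 both lie within the usual scatter of this assay, so the three numbers read as one level.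

Within the data shown here, the only step between two compounds that differ in a single place is a number 5 percentage points lower from compound 1 to compound 2 (within the scatter). It rests on (the fact that compounds 1 and 2 differ only in the configuration as drawn), and it says nothing about swapping one group for another.

Compound 4, `C[C@H](NC(=O)Nc1ccccc1Br)c1ccccc1`, is not yet measured. It differs from compound 2 by bromo in place of isopropyl on an aromatic carbon. Among the measured compounds shown here, no measured step exchanges a group on that ring, so the expectation can lean only on the fact that all three numbers sit at one level. The step from compound 2 to compound 4 is therefore expected to be small, a number 2 percentage points higher from compound 2 to compound 4 (within the scatter), not beyond the scatter in either direction. Compound 4 is estimated at 98%, with a range from 88% to 108%.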

Compound 4, a percentage reported as activity, at one concentration (the size of the read-out at that concentration, not a potency): 99%
Compound 4: middle estimate off by 1 percentage points, on the low side; the range from low to high includes it.
By their numbers in this assay, from the lowest: compounds 2, 4, 3 and 1 (each within the scatter of the next).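

Bromo in place of isopropyl on an aromatic carbon is the first exchange of one group for another in this series, and in this assay it reads as a number 3 percentage points higher from compound 2 to compound 4 (within the scatter). Among these compounds, at this place on the six-membered aromatic ring, a group of 3 heavy atoms, all carbon, gives way to a single bromine without the number leaving the one level shared by the earlier compounds, so this exchange separates neither compound from the other. Nothing measured here offers a reason why the number holds through this exchange.

Whether any group on this aromatic carbon can move the number beyond the scatter stays open: an amine, a carboxylic acid or a longer chain there could read the same or could read differently, and the compounds shown give no hint of which. On these data alone, it also stays open whether the same exchange of isopropyl for bromo would read alike in the configuration drawn for compound 1, or on the ring position that carries the hexyl chain in compound 3.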